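The compounds below may be only part of what the source reports. "The series", "measured", "known", "first", "only" and "open" are said of these compounds alone.

Compound 3, with the structure `CCOC(=O)C1=C(Nc2ccccc2)S/C(=C\c2cccnc2)C1=O`, is the compound that stands lowest among the three measured here. In a functional assay on K562 cells (Homo sapiens) for inhibition, read by MTT assay, with a stated time of 72 h, tested at 10 uM (a lower number here means less inhibition, a higher number more inhibition at the concentration tested (going by the name of the read-out)), compound 3 gives only a limit of the assay, < 10%, and no number, as the limit of < 10% in this assay, at which 1 of the 3 values shown sits, records. Compound 1, `CCOC(=O)C1=C(Nc2ccccc2)S/C(=C\c2ccccc2)C1=O`, carries a phenyl in the same place and in this assay gives 42.9%. Compound 2, `CCOC(=O)C1=C(Nc2ccccc2)S/C(=C\c2ccc[nH]2)C1=O`, with the 1H-pyrrol-2-yl group, gives in this assay a value of 16.2%.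

The next compound, compound 4, has the structure `CCOC(=O)C1=C(Nc2ccccc2)S/C(=C\c2cc3ccncc3[nH]2)C1=O`. Its change from compound 3 is a group of 9 heavy atoms (7 carbon, 2 nitrogen; one five-membered aromatic ring with 1 hetero atom, one six-membered aromatic ring with 1 hetero atom) in place of a group of 6 heavy atoms (5 carbon, 1 nitrogen; one six-membered aromatic ring with 1 hetero atom), on a double-bonded chain carbon bound to a double-bonded ring carbon.

The measured steps that bear on this change are a number 26.7 percentage points lower from compound 1 to compound 2 (beyond the scatter), a number at least 32.9 percentage points lower from compound 1 to compound 3 (beyond the scatter) and a number at least 6.2 percentage points lower from compound 2 to compound 3 (that floor lies within the scatter). The five-membered ring with one hetero atom, present in compound 2, sat somewhat higher than the pyridin-3-yl of compound 3, though that gap lies within the scatter. A small rise beyond the limit, or none at all, is therefore expected in this assay for compound 4, the step being a number at least 5 percentage points higher from compound 3 to compound 4 (that floor lies within the scatter). The estimate for compound 4 in this assay is 15%, with a range from 5% to 30%.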

Compound 4, a percentage reported as inhibition, at one concentration (the size of the read-out at that concentration, not a potency): 22.8%
For compound 4 the middle estimate is 7.8 percentage points below the measured one; measured number inside the range.
By their numbers in this assay, from the lowest: compounds 2 and 4 (each within the scatter of the next); then compound 1. At a limit, below all of these: compound 3.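

In this assay, this position takes a larger group than the pyridin-3-yl, as the change to the group with one five-membered and one six-membered aromatic ring gives a number at least 12.8 percentage points higher from compound 3 to compound 4 (beyond the scatter) on the shared core. That larger group cannot be told apart from the 1H-pyrrol-2-yl, with a number 6.6 percentage points higher from compound 2 to compound 4 (within the scatter), yet it does not reach the phenyl, with a number 20.1 percentage points lower from compound 1 to compound 4 (beyond the scatter), so neither nitrogen-bearing group with a five-membered ring matches the phenyl here. The first step remains only a floor, since compound 3 sits at a limit of the assay and not at a number: the limit of < 10% in this assay, at which 1 of the 4 values shown sits.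

The compounds shown leave open whether the rise depends on the hydrogen-bond donor or on the size of the group. They also leave open how a phenyl carrying a methoxy group or a carboxylic acid would read at this place.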